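A few compounds are considered here, and "the series" means these few. Any claim that something is new, unique, unknown or untested is made for them only; others in the source may bear on it.

Measured compounds:
Compound 1 `Cc1ccc(CNc2nc(-c3ccccc3C(F)(F)F)nc3ccccc23)s1` gives 5100 nM in an assay on a protein complex for inhibition of ubiquitin carboxyl-terminal hydrolase 1/WD repeat-containing protein 48 (Homo sapiens), read by fluorescence; a lower number here means a stronger inhibitor, a higher number a weaker inhibitor.
Compound 2 `O=[N+]([O-])c1ccccc1-c1nc(NCc2ccc(-c3cccnc3)cc2)c2ccccc2n1` gives 7800 nM in this assay.
Compound 3 `CCc1ccccc1-c1nc(NCc2ccc(-c3cccnc3)cc2)c2ccccc2n1` gives 780 nM in this assay.

Compound 3 has the lowest number of the three and is therefore the strongest inhibitor among them; compound 1 comes nearest to it and compound 2 lies furthest away. Among the compounds with values here, the only change that touches a single place is the one from compound 2 to compound 3, which shows a 10-fold lower number from compound 2 to compound 3 (1.00 log units; beyond the scatter) and comes from putting ethyl in place of nitro on an aromatic carbon.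

Compound 4 `CC(C)c1ccccc1-c1nc(NCc2ccc(-c3cccnc3)cc2)c2ccccc2n1` has not yet been measured. It differs from compound 3 by methyl in place of hydrogen on a saturated chain carbon bound to an aromatic carbon and a saturated chain carbon, so that the ethyl group becomes isopropyl. Within the data shown here, no measured pair shows this kind of change: the step from compound 2 to compound 3 exchanges two quite unlike groups, and compound 1 differs from compound 3 in another part of the structure altogether. Adding one carbon to a chain that is already present is a smaller alteration than either of those. The expected result is therefore a step of about a 1.3-fold lower number from compound 3 to compound 4 (0.11 log units; within the scatter) in this assay, which may well fall within the scatter. Compound 4 is estimated at 600 nM, with a range from 200 nM to 2000 nM.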

Compound 4, half-maximal inhibitory concentration: 180 nM
Compound 4: middle estimate off by 3.3-fold (0.52 log units), on the high side, and the stated range ends above it.
By their numbers in this assay, from the lowest: compound 4; then compound 3; then compounds 1 and 2 (each within the scatter of the next).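

Adding one methyl to the ethyl group, which turns 2-ethylphenyl into 2-isopropylphenyl, gives a 4.3-fold lower number from compound 3 to compound 4 (0.64 log units; beyond the scatter) in this assay and so moves the result beyond the scatter. Within the data shown here, the earlier compounds showed only that this group can be exchanged for a very different one, whereas this step shows that even a single added carbon on the saturated chain carbon changes the number. Set against nitro, isopropyl gives a 43-fold lower number from compound 2 to compound 4 (1.64 log units; beyond the scatter) and is the largest step seen so far. Nothing measured here explains why the added methyl has this effect. As far as these compounds go, whether the number keeps falling with a still larger branched group such as tert-butyl, or changes with a small ring such as cyclopropyl, remains open. From the compounds shown here alone, it is also open whether isopropyl would give a similar step on the rest of the structure of compound 1.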